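The source may report more compounds than this note shows. Statements on the series, on what has been measured and on what is new or still open speak of the compounds shown alone.

Compound 1 `CC(C)C[C@H](N)CN(C(=O)C(C)Cc1ccccc1)c1ccc(-c2ccccc2)cc1` and compound 2 `CC(C)C[C@@H](N)CN(C(=O)[C@@H]1C[C@H]1c1ccccc1)c1ccc(-c2ccccc2)cc1` mark the potent end of this small set: in a functional assay for agonist activity at G protein-coupled receptor 88 (Homo sapiens), read by HTRF and cAMP accumulation (on this read-out lower numbers stand for an effect already at smaller amounts and higher numbers for an effect only at larger amounts of compound), compound 1 gives 1.2 nM, and compound 2 gives 1.8 nM. Compound 3 `CC[C@H](C)[C@H](N)CN(C(=O)[C@@H]1C[C@H]1c1ccccc1Cl)c1ccc(-c2ccccc2)cc1` stands far from both. For compound 3 this assay reports no number but only a limit, > 25000 nM, which is the limit of > 25000 nM in this assay, at which 1 of the 3 values shown sits. Compound 4 `CC[C@H](C)[C@H](N)CN(C(=O)[C@@H]1C[C@H]1c1ccccn1)c1ccc(-c2ccccc2)cc1` has not yet been measured; it differs from compound 3 in that (pyridin-2-yl in place of 2-chlorophenyl on a saturated ring carbon). Within the data shown here, no measured pair isolates this change, and compound 3 offers no number from which a step could be sized. In this assay the change is expected to register as an at least 3.1-fold lower number from compound 3 to compound 4 (0.49 log units; beyond the scatter), toward smaller amounts of compound, though with little firm ground. Compound 4 is therefore expected to give 8000 nM, within 400 nM to 25000 nM, and it may well return only a limit again.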

Compound 4, half-maximal effective concentration: 130 nM
Beside the measured number, compound 4's estimate is 62-fold (1.79 log units) above it; measured number outside the range, below it.
By their numbers in this assay, from the lowest: compounds 1 and 2 (each within the scatter of the next); then compound 4. At a limit, above all of these: compound 3.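

Among these compounds, at this saturated ring carbon, pyridin-2-yl in place of 2-chlorophenyl gives in this assay an at least 190-fold lower number from compound 3 to compound 4 (2.28 log units; beyond the scatter), the first change in this set whose effect can be read in one place. With the rest of the molecule unchanged, the group on the three-membered ring alone separates a limit from a measurable number. The size is only a minimum, because compound 3 has no number of its own: the limit of > 25000 nM in this assay, at which 1 of the 4 values shown sits.

On these data alone, what stays open is whether losing the chlorine or gaining the ring nitrogen carries the step, which a plain phenyl at this carbon would separate. Also open, as far as these compounds go, is how a thienyl ring would fare here.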